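Methyl on the Five-Membered Ring: Working Notes on Agonist Potency

The compounds below may be only part of what the source reports. "The series", "measured", "known", "first", "only" and "open" are said of these compounds alone.

All three measured compounds were tested in an in vitro functional assay on cells (Fibroblast) for agonist activity at Alpha-1A adrenergic receptor (Homo sapiens); on this read-out lower numbers stand for an effect already at smaller amounts and higher numbers for an effect only at larger amounts of compound.

Compound 1 `Cn1ncnc1-c1ccccc1NCC1=NCCN1`: 2 nM
Compound 2 `Cc1nc(-c2ccccc2NCC2=NCCN2)n(C)n1`: 1000 nM
Compound 3 `Cn1cccc1-c1ccccc1NCC1=NCCN1`: 20 nM

Compound 1 is the reference point of the series. The change methyl in place of hydrogen on an aromatic carbon produces a 500-fold higher number from compound 1 to compound 2 (2.70 log units; beyond the scatter), the widest gap among the three. Exchanging the five-membered ring, (1-methyl-1H-pyrrol-2-yl in place of 1-methyl-1H-1,2,4-triazol-5-yl on an aromatic carbon), produces a 10-fold higher number from compound 1 to compound 3 (1.00 log units; beyond the scatter), so compound 3 stands between the other two. Compound 2 and compound 3 are not linked by a single change; their two values simply show that compound 2 gives the higher number.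

Compound 4 `Cc1ccc(-c2ccccc2NCC2=NCCN2)n1C` is not yet measured. It differs from compound 3 by methyl in place of hydrogen on an aromatic carbon. This is the same kind of change as from compound 1 to compound 2, but the place is not the same: in compound 2 the methyl sits between two ring nitrogen atoms, two ring bonds from the ring atom that bears a methyl group, whereas in compound 4 it sits next to the ring nitrogen and next to the ring atom that bears a methyl group, on a ring with one nitrogen rather than three.

For compound 4 a large step is expected, a 75-fold higher number from compound 3 to compound 4 (1.88 log units; beyond the scatter). This expectation rests on the earlier step of the same kind, a 500-fold higher number from compound 1 to compound 2 (2.70 log units; beyond the scatter), tempered by the different place and ring. Compound 4 is estimated at 1500 nM, with a range from 200 nM to 10000 nM.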

Compound 4, half-maximal effective concentration: 50.1 nM
Estimate against measurement, compound 4: 30-fold (1.48 log units) above; measured number outside the range, below it.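

In this assay, methyl in place of hydrogen on an aromatic carbon gives a 2.5-fold higher number from compound 3 to compound 4 (0.40 log units; beyond the scatter), a modest step where the core of compound 1 gave a large one. Both steps run in the same direction, but their sizes do not match: the same change on two cores in this assay, a 500-fold higher number (2.70 log units; beyond the scatter) from compound 1 to compound 2 and a 2.5-fold higher number (0.40 log units; beyond the scatter) from compound 3 to compound 4, 200-fold (2.30 log units) apart, beyond the scatter of two such steps

In these two pairs the direction of the change carries over from one core to the other and its size does not, so the step on one core gives no reliable figure for the other. The pairs do not show what sets the size, since the methyl stands at a different place in each and the ring also differs, with one nitrogen rather than three, and place and ring cannot be separated here.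

Going by these compounds, whether an ethyl group, a methoxy group or an amine in place of the same hydrogen would also give steps of unequal size on the two cores stays open. So does the size of the methyl step on a third core.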